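A Second Chloro Placed on the Core of Compound 3

This account rests on a few compounds, and the source may have more. Where it says the series, first, only, none or still open, it means among the compounds named here.

Three close relatives of one shared core have been tested in a functional assay on SF-295 cells (Homo sapiens) for cytotoxicity, read by sulforhodamine B assay, with a stated time of 48 h; on this read-out lower numbers stand for stronger inhibition of growth and higher numbers for weaker inhibition of growth. Compound 1 `ClCc1ccccc1Cn1cnc2c(Cl)ncnc21` gives 23400 nM, and compound 2 `ClCc1cccc(Cn2cnc3ncnc(Cl)c32)c1` gives 19100 nM. Compound 3 `ClCc1cccc(Cn2cnc3c(Cl)ncnc32)c1` gives 8700 nM, the lowest of the three numbers and beyond the usual scatter from both of the others, so it is the strongest growth inhibitor of this set. Compound 4 `ClCc1cccc(Cn2cnc3c(Cl)nc(Cl)nc32)c1` differs from compound 3 in one place: chloro in place of hydrogen on an aromatic carbon, the new chloro sitting between two ring nitrogen atoms. Going by the values given here, no measured pair shows what this change does, so the expectation leans on compound 3 alone. The step from compound 3 to compound 4 is expected to be a 1.5-fold lower number from compound 3 to compound 4 (0.16 log units; within the scatter), small and at most slightly toward stronger inhibition. Compound 4 is estimated at 6000 nM, with a likely range from 2000 nM to 18000 nM.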

Compound 4, concentration for total growth inhibition: 17000 nM
Estimate against measurement, compound 4: 2.8-fold (0.45 log units) below; low and high end bracket the measured number.
By their numbers in this assay, from the lowest: compounds 3, 4, 2 and 1 (each within the scatter of the next, the first and the last beyond it).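

In this assay, going by these compounds alone, chloro in place of hydrogen on an aromatic carbon, between two ring nitrogen atoms, gives a 2.0-fold higher number from compound 3 to compound 4 (0.29 log units; within the scatter), the first reading for this position. The position therefore carries a chloro without a shift beyond the usual scatter, so this one swap gives no clear gain or loss in growth inhibition. Nothing on hand explains the result.

Going by these compounds, whether an amine or a methoxy group on this same carbon would shift the number beyond the scatter stays open. So does whether this chloro would give a similar step on compound 1 or compound 2.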